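A few compounds are considered here, and "the series" means these few. Any claim that something is new, unique, unknown or untested is made for them only; others in the source may bear on it.

Compound 1 `Cc1cc(Nc2cc(-c3ccccc3)[nH]n2)n2nc(SCCCc3ccccc3)nc2n1` gives 5030 nM in a functional assay on PC-9 cells (Homo sapiens) for inhibition, read by MTT assay, with a stated time of 72 h (a higher number here means a weaker inhibitor, a lower number a stronger inhibitor), and carries the highest of the two numbers shown. Compound 2 `Cc1cc(Nc2cc(-c3ccccc3)[nH]n2)n2nc(SCc3csc4ccccc34)nc2n1` gives 4420 nM, so that a 1.1-fold lower number from compound 1 to compound 2 (0.06 log units; within the scatter). For compound 3 `C#CCSc1nc2nc(C)cc(Nc3cc(-c4ccccc4)[nH]n3)n2n1` this assay reports only a limit, > 50000 nM. Compound 4 `Cc1cc(Nc2cc(-c3ccccc3)[nH]n2)n2nc(SCC(=O)c3ccccc3)nc2n1` is not yet measured; it differs from compound 1 in that (benzoyl in place of phenethyl on a saturated chain carbon bound to a sulfur). Among the compounds with values here, the steps that bear on it are an at least 9.9-fold higher number from compound 1 to compound 3 (0.99 log units; beyond the scatter) and an at least 11-fold higher number from compound 2 to compound 3 (1.05 log units; beyond the scatter), where the ring-bearing group is lost, against a 1.1-fold lower number from compound 1 to compound 2 (0.06 log units; within the scatter), where one ring-bearing group replaces another. Compound 4 keeps a six-membered aromatic ring on the chain, so a step nearer the scatter than the loss seen with compound 3 is expected, leaning weaker. For compound 4 the estimate is 7500 nM, between 2500 nM and 25000 nM. This means an expected 1.5-fold higher number from compound 1 to compound 4 (0.17 log units; within the scatter).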

Compound 4, half-maximal inhibitory concentration: 4450 nM
The estimate for compound 4 lay 1.7-fold (0.23 log units) above the measured number; the range from low to high includes it.
By their numbers in this assay, from the lowest: compounds 2, 4 and 1 (each within the scatter of the next). At a limit, above all of these: compound 3.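

Placing benzoyl on the saturated chain carbon bound to a sulfur brings in a carbonyl and a hydrogen-bond acceptor, yet the number stays within the scatter (a 1.1-fold lower number from compound 1 to compound 4 (0.05 log units; within the scatter)). The same holds against the 1-benzothiophen-3-yl group (a 1.0-fold higher number from compound 2 to compound 4 (0.00 log units; within the scatter)), so this position tolerates that acceptor in compounds 1, 2 and 4, while the ethynyl of compound 3 stands apart (an at least 11-fold lower number from compound 3 to compound 4 (1.05 log units; beyond the scatter)). For compound 3 the value is a limit, so that step has no exact size: the limit of > 50000 nM in this assay, at which 1 of the 4 values shown sits.

Open, from the compounds shown here alone, is whether an amine or a carboxylic acid on this chain would separate from compounds 1, 2 and 4. Going by these compounds, a longer chain carrying the phenyl ring also remains open.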